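This account rests on a few compounds, and the source may have more. Where it says the series, first, only, none or still open, it means among the compounds named here.

Three compounds have been measured in a functional assay on SMMC-7721 cells (Homo sapiens) for cytotoxicity, read by MTT assay, with a stated time of 24 h; on this read-out higher numbers stand for weaker inhibition and lower numbers for stronger inhibition:

Compound 1, `CN1C/C(=C\c2cccnc2)C(=O)/C(=C/c2ccccc2C(F)(F)F)C1`, gives 3900 nM.
Compound 2, `CN1C/C(=C\c2ccc(C(F)(F)F)cc2)C(=O)/C(=C/c2cccnc2)C1`, gives 4830 nM.
Compound 3, `CN1C/C(=C\c2ccncc2)C(=O)/C(=C/c2ccccc2C(F)(F)F)C1`, gives 4100 nM.

The three numbers lie close together, and no two of them are separated by more than the ordinary scatter of this kind of measurement. Compound 1 and compound 3 share a core and differ in one place only: pyridin-4-yl in place of pyridin-3-yl on a double-bonded chain carbon bound to a double-bonded ring carbon. That change made a 1.1-fold higher number from compound 1 to compound 3 (0.02 log units; within the scatter). The difference between the core of compound 1 and the core of compound 2 is not broken down here.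

Compound 4, `CN1C/C(=C\c2ccncc2)C(=O)/C(=C/c2ccc(C(F)(F)F)cc2)C1`, has not yet been measured in this assay. Among the compounds with values here, it differs from compound 2 by pyridin-4-yl in place of pyridin-3-yl on a double-bonded chain carbon bound to a double-bonded ring carbon, which is the same change, in the same place, as the one from compound 1 to compound 3.

Since that change barely moved the number once, the step is expected to be a 1.1-fold higher number from compound 2 to compound 4 (0.02 log units; within the scatter), a judgment that rests on compound 1 and compound 3 because the same change produced a 1.1-fold higher number from compound 1 to compound 3 (0.02 log units; within the scatter) there. Compound 4 is therefore estimated at 5100 nM, with a likely range from 2900 nM to 9000 nM.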

Compound 4, half-maximal inhibitory concentration: 17700 nM
The estimate for compound 4 lay 3.5-fold (0.54 log units) below the measured number; measured number above the stated range.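

In this assay, putting pyridin-4-yl in place of pyridin-3-yl gave a 3.7-fold higher number from compound 2 to compound 4 (0.56 log units; beyond the scatter), so a swap that left the number essentially unmoved on one core did not behave the same way on the other: the same change on two cores in this assay, a 1.1-fold higher number (0.02 log units; within the scatter) from compound 1 to compound 3 and a 3.7-fold higher number (0.56 log units; beyond the scatter) from compound 2 to compound 4, 3.5-fold (0.54 log units) apart, beyond the scatter of two such steps.
This shows that, within these two pairs, the size of the step depends on the core carrying the change, and that a result from one core is not a safe guide to the other. It does not show which feature of the two cores is responsible, or which of the two steps would be the more typical for the series, and two pairs are too few to settle either question.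

As far as these compounds go, whether the same swap on a further core would resemble either step remains open. Also open, from the compounds shown here alone, is how the numbers would respond if a nitrile or an amine stood in place of the trifluoromethyl group on either core.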